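The source may hold more compounds than are shown below. What is called first, only, known or untested is meant among the compounds shown, and "the series" means these compounds.

Compound 1 `CCCCNC(=O)c1c(O)c2cccnc2n(-c2ccccc2)c1=O` and compound 2 `O=C(Nc1ccccc1)c1c(O)c2cccnc2n(-c2ccccc2)c1=O` share one core and differ only in the group carried on the amide-type nitrogen. In a functional assay on the whole organism for inhibition, with Rattus norvegicus as the target, read by cytopathic effect and paw edema, at a dose of 100 mg/kg by the oral route (on this read-out higher numbers stand for more inhibition at the one dose given (going by the name of the read-out) and lower numbers for less inhibition), compound 1 gives 20.4%. In this assay, among the compounds with values here, compound 2 gives -15%, the lowest of the two numbers measured so far; the one measured step, a number 35.4 percentage points lower from compound 1 to compound 2 (beyond the scatter), separates it from its nearest neighbour. Compound 3 `O=C(Nc1ccc(Cl)cc1)c1c(O)c2cccnc2n(-c2ccccc2)c1=O` has not yet been measured. It differs from compound 2 in a single place: chloro in place of hydrogen on an aromatic carbon. Within the data shown here, this is a different kind of change from the measured step, which exchanged phenyl for butyl on the amide-type nitrogen, so no measured pair shows what chloro in place of hydrogen on an aromatic carbon does in this setting. With nothing pointing in either direction, the step expected in this assay is a number 10 percentage points higher from compound 2 to compound 3 (within the scatter), which means no change beyond the scatter is expected. For compound 3 the estimated value in this assay is -5%, with a range from -30% to 25%.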

Compound 3, a percentage reported as inhibition, in the whole organism at one dose (the size of the read-out at that dose, not a potency): 2.5%
Compound 3: middle estimate off by 7.5 percentage points, on the low side; the measured number falls inside the stated range.
By their numbers in this assay, from the lowest: compound 2; then compound 3; then compound 1.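

In this assay, chloro in place of hydrogen on an aromatic carbon, para to a large group, gives a number 17.5 percentage points higher from compound 2 to compound 3 (beyond the scatter), so a change of one heavy atom on this ring can alter the result in the whole animal, which the earlier swap of one entire group on the amide-type nitrogen could not show. The chloro recovers only part of the ground lost when phenyl replaced butyl, as the comparison with the butyl compound still reads a number 17.9 percentage points lower from compound 1 to compound 3 (beyond the scatter), leaving 4-chlorophenyl on this nitrogen behind butyl at this one dose. Nothing available explains why the chloro raises the number or why butyl stays ahead of 4-chlorophenyl.

The compounds shown leave open whether this rise belongs to chloro itself or would also appear with another group on the same carbon, such as a methoxy group, an amine or a carboxylic acid. They also leave open whether a longer chain than butyl on the amide-type nitrogen would give a higher or lower number than butyl does.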